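This account rests on a few compounds, and the source may have more. Where it says the series, first, only, none or still open, it means among the compounds named here.

Compound 1: `C/C(=C\c1cc(-c2ccc(C)cc2)co1)C(N)=O`, 12000 nM
Compound 2: `C/C(=C\c1cc(-c2ccc(C#N)cc2)cs1)C(N)=O`, 250 nM

In a functional assay on HeLa cells (Homo sapiens) for cytotoxicity, read by CCK-8 assay, with a stated time of 24 h (on this read-out lower numbers stand for stronger inhibition and higher numbers for weaker inhibition), compound 2 stands at the lower of the two numbers. The nearest measured compound is compound 1, and its number in this assay lies well beyond the scatter above that of compound 2; the two differ from each other in more than one place, so the pair allows no single-change comparison.

Compound 3 is `C=Cc1ccc(-c2csc(/C=C(\C)C(N)=O)c2)cc1`. It departs from compound 2 by one change: vinyl in place of cyano on an aromatic carbon. Among the measured compounds shown here, no measured pair in this set isolates this change, so its size cannot be read from a known step. The estimate is therefore drawn from the value of compound 2 in this assay, 250 nM, with a wide allowance. Compound 3 is expected to give a somewhat higher number, a step from compound 2 of about a 2.4-fold higher number from compound 2 to compound 3 (0.38 log units; beyond the scatter), modest but plausibly beyond the scatter. The estimated value for compound 3 in this assay is 600 nM, within a range from 200 nM to 2500 nM.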

Compound 3, half-maximal inhibitory concentration: > 50000 nM
Compound 3 gave a limit, no number; the forecaster's own chance of this, stated with the estimate: 5%; at least 83-fold (1.92 log units) between middle value and limit.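

In this assay, vinyl in place of cyano, on an aromatic carbon of a six-membered aromatic ring of carbon only and para to a large group, brings an at least 200-fold higher number from compound 2 to compound 3 (2.30 log units; beyond the scatter). Compound 3 gives > 50000 nM, which is a limit of the assay and not a number, so the step has a floor but no measured size: the limit of > 50000 nM in this assay, at which 1 of the 3 values shown sits. Compound 1 and compound 2 differ in more than one place and could say nothing about any single position, whereas this pair shows that a change of two heavy atoms at this one place is enough to move the read-out far beyond the scatter.

The compounds shown leave open whether this outcome follows from the loss of cyano or the entry of vinyl, and an amine or a carboxylic acid at the same place would be needed to begin separating the two. They also leave open whether the same exchange would have a step of similar size on the core of compound 1, and they give no reason for the size of this one.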